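The compounds below may be only part of what the source reports. "The series", "measured", "known", "first", "only" and "open" are said of these compounds alone.

Compounds measured in a functional assay on SK-BR-3 cells (Homo sapiens) for antiproliferative activity, read by MTT assay, with a stated time of 72 h; a lower number here means a stronger inhibitor, a higher number a weaker inhibitor:
compound 1, `C#CCOC(=O)C[C@@H]1C(C(=O)OC)=CO[C@@H](O[C@@H]2O[C@H](COC(C)=O)[C@@H](OC(C)=O)[C@H](OC(C)=O)[C@H]2OC(C)=O)/C1=C/C`, gives > 15000 nM, a limit of the assay and not a number.
compound 2, `C/C=C1/[C@H](O[C@@H]2O[C@H](COC(C)=O)[C@@H](OC(C)=O)[C@H](OC(C)=O)[C@H]2OC(C)=O)OC=C(C(=O)OC)[C@H]1CC(=O)O`, gives > 15000 nM, a limit of the assay and not a number.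
compound 3, `C/C=C1/[C@H](O[C@@H]2O[C@H](COC(C)=O)[C@@H](OC(C)=O)[C@H](OC(C)=O)[C@H]2OC(C)=O)OC=C(C(=O)OC)[C@H]1CC(=O)SCCc1ccccc1`, gives > 15000 nM, a limit of the assay and not a number.

Compound 3 therefore stands at the same limit as the other two, and nothing in these numbers sets it apart from them. The step from compound 3 to compound 4, `C/C=C1/[C@H](O[C@@H]2O[C@H](COC(C)=O)[C@@H](OC(C)=O)[C@H](OC(C)=O)[C@H]2OC(C)=O)OC=C(C(=O)OC)[C@H]1CC(=O)OC`, is methoxy in place of phenethylsulfanyl on a carbonyl carbon.

Two measured steps end at compound 3 and bear on this change. The step that the two limits leave unreadable from compound 1 to compound 3 and the step that the two limits leave unreadable from compound 2 to compound 3 both lie between limits, so their size cannot be read. The same holds for a step that the two limits leave unreadable from compound 1 to compound 2. What the three measurements share is the limit of > 15000 nM in this assay, at which 3 of the 3 values shown sit: every change so far at this carbonyl carbon, whether the group on it was propargyloxy, hydroxy or phenethylsulfanyl, has left the value at the limit.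

With methoxy in place of phenethylsulfanyl on the same carbonyl carbon, no step beyond the scatter is expected in this assay, and the step that the limit leaves unreadable from compound 3 to compound 4 is the expected outcome. Compound 4 is estimated at 20000 nM, within 5000 nM to 60000 nM, most likely reported again as a limit.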

Compound 4, half-maximal inhibitory concentration: > 15000 nM
Compound 4: no number, only a limit; the forecaster's own chance of this, stated with the estimate: 85%; the middle value is on the limit's open side.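

In this assay compound 4 gives > 15000 nM, a limit of the assay and not a number. No step to compound 4 from compound 1, compound 2 or compound 3 can be read, and the four compounds share one result: the limit of > 15000 nM in this assay, at which 4 of the 4 values shown sit.

The compounds shown leave open whether any group on this carbonyl carbon would give a measurable value in this assay.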